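This account rests on a few compounds, and the source may have more. Where it says the series, first, only, none or still open, it means among the compounds named here.

Measured so far:
compound 1, `CC(C)c1ccc(-c2nc(SCc3cn(CC(=O)NC(=O)Nc4ccccn4)nn3)nc(Nc3ccccc3Cl)c2C#N)cc1`, gives 23400 nM
compound 2, `CC(C)c1ccc(-c2nc(SCc3cn(CC(=O)NC(=O)Nc4ccccn4)nn3)nc(Nc3ccc(Cl)cc3)c2C#N)cc1`, gives 11200 nM
compound 3, `COc1ccc(Nc2nc(SCc3cn(CC(=O)NC(=O)Nc4ccccn4)nn3)nc(-c3ccc(C(C)C)cc3)c2C#N)cc1`, gives 5420 nM

All three were tested in a functional assay on ECa-109 cells (Homo sapiens) for inhibition, read by MTT assay, with a stated time of 72 h; a higher number here means a weaker inhibitor, a lower number a stronger inhibitor. Compound 1 stands highest of the three numbers, meaning it is the weakest inhibitor shown here. Its nearest neighbour is compound 2, with a 2.1-fold lower number from compound 1 to compound 2 (0.32 log units; beyond the scatter), and its furthest is compound 3, with a 4.3-fold lower number from compound 1 to compound 3 (0.64 log units; beyond the scatter). Between those two, a 2.1-fold lower number from compound 2 to compound 3 (0.32 log units; beyond the scatter).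

Compound 4, `CC(C)c1ccc(Nc2nc(SCc3cn(CC(=O)NC(=O)Nc4ccccn4)nn3)nc(-c3ccc(C(C)C)cc3)c2C#N)cc1`, has not yet been measured. It differs from compound 1 in one place: 4-isopropylphenyl in place of 2-chlorophenyl on a nitrogen on an aromatic ring.

The two steps that bear on this change both start from compound 1 and also replace 2-chlorophenyl with a differently substituted phenyl on the same nitrogen. Each of them gave a lower number, of modest size, and both lay beyond the usual scatter. Whether isopropyl behaves like chloro or like methoxy in that position is not shown by any measured pair, so the expectation is for a lower number of roughly that modest size, with the range covering both outcomes. Compound 4 is therefore expected to give about 9000 nM, between 3500 nM and 23000 nM, which would mean an estimated 2.6-fold lower number from compound 1 to compound 4 (0.41 log units; beyond the scatter).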

Compound 4, half-maximal inhibitory concentration: 2490 nM
Beside the measured number, compound 4's estimate is 3.6-fold (0.56 log units) above it; measured number below the stated range.
By their numbers in this assay, from the lowest: compound 4; then compound 3; then compound 2; then compound 1.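

In this assay, 4-isopropylphenyl on this nitrogen gives the largest drop so far from the 2-chlorophenyl of compound 1 (a 9.4-fold lower number from compound 1 to compound 4 (0.97 log units; beyond the scatter)), and compound 4 now has the lowest number of the four, with its steps to all the others beyond the scatter. Moving the chlorine was therefore not the whole story, since the choice of group on the phenyl ring also matters: there is a 4.5-fold lower number from compound 2 to compound 4 (0.65 log units; beyond the scatter) for isopropyl in place of chloro, and a 2.2-fold lower number from compound 3 to compound 4 (0.34 log units; beyond the scatter) for isopropyl in place of methoxy, which gives the order isopropyl, methoxy, chloro from lowest number to highest among these three compounds. Nothing available here gives a measured reason for that order.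

Three groups cannot show whether the number keeps falling with a bulkier carbon group such as tert-butyl or a longer chain such as hexyl, or whether an amine or a carboxylic acid in place of isopropyl would fit the same order. Going by these compounds, these results also come from a single cell line, so it remains open whether the order holds in other cells.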